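The compounds below may be only part of what the source reports. "The series", "measured", "known", "first", "only" and "open" are said of these compounds alone.

Measured so far:
- compound 1, `COc1cc(Cl)cc(-c2nn(-c3cccc(NC(=O)c4cccc(C(F)(F)F)c4)c3)cc2-c2ccncc2)c1`: 103%
- compound 2, `O=C(Nc1cccc(-n2cc(-c3ccncc3)c(-c3cc(O)cc(Cl)c3)n2)c1)Nc1ccc(Cl)c(Cl)c1`: 109%

Both numbers come from a functional assay on NCI/ADR-RES cells (Homo sapiens) for inhibition, read by sulforhodamine B assay, with a stated time of 48 h, tested at 0.01 uM; a lower number here means a stronger effect, a higher number a weaker effect of the compound at the concentration tested. In that test compound 1 gives 103% and compound 2 gives 109%; each reading sits at the level expected for cells left untreated, so at this concentration neither compound produces a measurable effect. Compound 2 stands at one end of the two numbers, but compound 1 lies within the scatter of it, and the two cannot be told apart.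

Compound 3, `COc1cc(Cl)cc(-c2nn(-c3cccc(NC(=O)Nc4ccc(Cl)c(Cl)c4)c3)cc2-c2ccncc2)c1`, is the next compound and has not yet been measured. Relative to compound 2 the change is small: methyl in place of hydrogen on an oxygen on an aromatic ring. Compound 1 already carries the methoxy group and shows no effect, which gives no hint that the methyl alone would bring activity. Going by the values given here, no measured step exists for this pair, so the expectation rests on the flat picture of compounds 1 and 2: a step in the assay of no size beyond the scatter, in no particular direction, is expected. For compound 3 the estimated reading is 105%, within 94% to 116%, which means an expected step of a number 4 percentage points lower from compound 2 to compound 3 (within the scatter).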

Compound 3, a percentage reported as activity, at one concentration (the size of the read-out at that concentration, not a potency): 97%
Compound 3: the middle estimate sits 8 percentage points above what was measured, and the stated range covers the measured number.
By their numbers in this assay, from the lowest: compounds 3, 1 and 2 (each within the scatter of the next, the first and the last beyond it).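

In this assay, methyl in place of hydrogen on the oxygen of the 3-chloro-5-hydroxyphenyl group gives a number 12 percentage points lower from compound 2 to compound 3 (beyond the scatter) in this pair, the first difference in the series that lies beyond the usual scatter, so this oxygen is a place where a small change can register, though the step is only modest and compound 3 at 97% still reads close to the level expected for untreated cells. The other exchange, (3,4-dichlorophenyl)amino in place of 3-(trifluoromethyl)phenyl on a carbonyl carbon, gives a number 6 percentage points lower from compound 1 to compound 3 (within the scatter) and so cannot be told apart from no change at this concentration. Nothing at hand explains why the methyl step occurs.

From the compounds shown here alone, it remains open whether a longer chain on this oxygen, such as ethoxy, or an amine in place of the hydroxy or methoxy group, would move the reading further in the same direction. With one low concentration and readings that stay near the untreated level, the potency of these compounds at higher concentrations also remains unknown.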